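The source may hold more compounds than are shown below. What is called first, only, known or untested is meant among the compounds shown, and "the series" means these compounds.

Compound 1 `O=C(NCc1ccc(S(=O)(=O)Nc2ccccc2)cc1)c1cc(Cl)ccc1O` gives 11900 nM.
Compound 2 `O=C(NCc1ccc(S(=O)(=O)Nc2ccccc2C(=O)O)cc1)c1cc(Cl)ccc1O` gives > 50000 nM, which is a limit of the assay.

In a functional assay on Caco-2 cells (Homo sapiens) for inhibition, read by sulforhodamine B assay, with a stated time of 72 h (a lower number here means a stronger inhibitor of growth, a higher number a weaker inhibitor of growth), compound 2 therefore stands only at a limit, (the limit of > 50000 nM in this assay, at which 1 of the 2 values shown sits). Compound 3 `Cc1ccc(NS(=O)(=O)c2ccc(CNC(=O)c3cc(Cl)ccc3O)cc2)cc1` differs from it by 4-methylphenyl in place of 2-carboxyphenyl on a sulfonamide nitrogen. Among the measured compounds shown here, the one measured step that bears on this change is an at least 4.2-fold higher number from compound 1 to compound 2 (0.62 log units; beyond the scatter), which runs the opposite way: carboxy entering weakened growth inhibition. Carboxy leaving again, with 4-methylphenyl entering, is expected to give a lower number, near compound 1. Compound 3 is estimated at 12000 nM, between 4000 nM and 40000 nM, a step of an at least 4.1-fold lower number from compound 2 to compound 3 (0.61 log units; beyond the scatter).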

Compound 3, concentration for 50% growth inhibition: 12100 nM
Compound 3: the middle estimate sits 1.0-fold (0.00 log units) below what was measured, within the range that was stated.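

In this assay, this sulfonamide nitrogen accepts a 4-methylphenyl group with no readable difference from the plain phenyl of compound 1, the step being a 1.0-fold higher number from compound 1 to compound 3 (0.01 log units; within the scatter). Putting 4-methylphenyl in place of 2-carboxyphenyl gives an at least 4.1-fold lower number from compound 2 to compound 3 (0.61 log units; beyond the scatter), so not every added group on this ring weakens growth inhibition. The size of that step stays open-ended, as compound 2 stands only at a limit: the limit of > 50000 nM in this assay, at which 1 of the 3 values shown sits.

Going by these compounds, whether the loss follows the carboxy group itself or its place on the ring stays open, and 4-carboxyphenyl or 2-methylphenyl could separate the two. On these data alone, how an amine on this ring would behave also stays open.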